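Swapping the Aryl Group on Sulfur

The source may hold more compounds than are shown below. What is called first, only, known or untested is meant among the compounds shown, and "the series" means these compounds.

Compound 1 `Nc1ccccc1NC(=O)c1ccc(CSc2cccc(F)c2)cc1`: 37.7%
Compound 2 `Nc1ccccc1NC(=O)c1ccc(CSc2ccc(F)cc2)cc1`: 19.4%

Within the data shown here, in a functional assay on A-375 cells (Homo sapiens) for inhibition, read by CCK-8 assay, with a stated time of 72 h, tested at 2 uM (on this read-out lower numbers stand for less inhibition of growth and higher numbers for more inhibition of growth at the one concentration tested), compound 2 gives 19.4%, the lower of the two numbers so far. Compound 3 `Cc1cc(C)cc(SCc2ccc(C(=O)Nc3ccccc3N)cc2)c1` differs from it in one place: 3,5-dimethylphenyl in place of 4-fluorophenyl on a sulfur. In words, 3,5-dimethylphenyl stands in place of 4-fluorophenyl on a sulfur. Among the measured compounds shown here, only one measured step bears on this: a number 18.3 percentage points lower from compound 1 to compound 2 (beyond the scatter), a modest change beyond the scatter, made on the same sulfur. For the measured compounds named here, no compound with a 3,5-dimethylphenyl group has been measured, so this guide is weak. A modest rise of similar size is expected, written as a number 13.6 percentage points higher from compound 2 to compound 3 (beyond the scatter). For compound 3 the estimated value is 33%, with an expected range of 14% to 55%.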

Compound 3, percent growth inhibition at one concentration: 48.5%
Estimate against measurement, compound 3: 15.5 percentage points below; low and high end bracket the measured number.
By their numbers in this assay, from the lowest: compound 2; then compound 1; then compound 3.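

Replacing fluorine with two methyl groups on the aryl ring gives a clear gain, with a number 29.1 percentage points higher from compound 2 to compound 3 (beyond the scatter) and a number 10.8 percentage points higher from compound 1 to compound 3 (beyond the scatter). Among these three compounds, the aryl group on sulfur therefore need not carry fluorine, and compound 3 stands above both fluorinated compounds. Nothing available explains why the 3,5-dimethylphenyl group does better.

From the compounds shown here alone, the two methyl groups enter together, so the share of each remains open. Going by these compounds, it also remains open how a methoxy group or an amine on this ring would compare.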